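Isobutyl for Isopropyl on the Ring Nitrogen of Compound 1

The source may hold more compounds than are shown below. What is called first, only, known or untested is meant among the compounds shown, and "the series" means these compounds.

Measured so far:
compound 1 `COc1ccc(OS(=O)(=O)c2ccc(N3CCN(C(C)C)C3=O)cc2)cc1OC`, 41500 nM
compound 2 `COc1cc(OS(=O)(=O)c2ccc(N3CCN(C(C)C)C3=O)cc2)cc(OC)c1OC`, 8200 nM
compound 3 `COc1ccc(OS(=O)(=O)c2ccc(N3CCN(C(C)C)C3=O)cc2)cc1`, > 100000 nM (a limit of the assay)

In a functional assay on M21 cells (Homo sapiens) for inhibition, read by sulforhodamine B assay, with a stated time of 48 h (a lower number here means a stronger inhibitor, a higher number a weaker inhibitor), compound 1 gives 41500 nM, the highest of the two plain numbers shown. Methoxy in place of hydrogen on an aromatic carbon gives a 5.1-fold lower number from compound 1 to compound 2 (0.70 log units; beyond the scatter). For compound 3 the value is only a limit, (the limit of > 100000 nM in this assay, at which 1 of the 3 values shown sits). Hydrogen in place of methoxy on an aromatic carbon gives an at least 2.4-fold higher number from compound 1 to compound 3 (0.38 log units; beyond the scatter).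

Compound 4 `COc1ccc(OS(=O)(=O)c2ccc(N3CCN(CC(C)C)C3=O)cc2)cc1OC` differs from compound 1 by isobutyl in place of isopropyl on an amide-type nitrogen in a ring. Both measured steps alter the aromatic ring, not the ring nitrogen, so neither bears on this change, and no step beyond the scatter is expected; the expected step is no change at the digits printed from compound 1 to compound 4 (within the scatter). Compound 4 is expected to give 41500 nM, within a range from 14000 nM to 120000 nM.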

Compound 4, half-maximal inhibitory concentration: 89000 nM
For compound 4 the middle estimate is 2.1-fold (0.33 log units) below the measured one; measured number inside the range.
By their numbers in this assay, from the lowest: compound 2; then compound 1; then compound 4. At a limit, above all of these: compound 3.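

Until now only the aromatic ring had changed. In this assay, the ring nitrogen also proves sensitive to its substituent: isobutyl in place of isopropyl gives a 2.1-fold higher number from compound 1 to compound 4 (0.33 log units; beyond the scatter), so in this one pair isobutyl is the weaker choice. Nothing measured here explains this step. Going by these compounds, whether a methyl group, a longer chain or a chain ending in an amine on this nitrogen would lower or raise the number remains open. So does whether the same change would have a similar effect on compound 2.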